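The source may report more compounds than this note shows. Statements on the series, on what has been measured and on what is new or still open speak of the compounds shown alone.

Values in an ADME assay on HEK293 cells (Homo sapiens) for cytotoxicity, read by fluorescence and resazurin assay, with a stated time of 24 h; a lower number here means that less compound is tolerated, a higher number that more compound is tolerated:
- compound 1 `O=S1(=O)C=C(Sc2nnc(-c3cccnc3)o2)c2ccccc21`: 4000 nM
- compound 2 `O=S1(=O)C=C(Sc2nnc(C3CCCCC3)o2)c2ccccc21`: 3000 nM
- compound 3 `O=S1(=O)C=C(Sc2nnc(-c3ccccn3)o2)c2ccccc21`: 5000 nM

Compound 3 is not separated from the other two: the record shows a 1.3-fold higher number from compound 1 to compound 3 (0.10 log units; within the scatter) and a 1.7-fold higher number from compound 2 to compound 3 (0.22 log units; within the scatter). Compound 4 `Cc1ccc(-c2nnc(SC3=CS(=O)(=O)c4ccccc43)o2)cc1` has 4-methylphenyl in place of pyridin-2-yl on an aromatic carbon. The measured steps that bear on this are swaps at the same place, and the remaining one is a 1.3-fold lower number from compound 1 to compound 2 (0.12 log units; within the scatter). None of the three leaves the scatter, even with the non-aromatic cyclohexyl of compound 2, so no step beyond the scatter is expected in this assay. The expected change is a 1.7-fold lower number from compound 3 to compound 4 (0.22 log units; within the scatter). For compound 4 the estimated value is 3000 nM, with an expected range of 1300 nM to 7000 nM.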

Compound 4, half-maximal cytotoxic concentration: 3000 nM
Compound 4: middle estimate and measured number agree at the digits printed, within the range that was stated.
By their numbers in this assay, from the lowest: compounds 2, 4, 1 and 3 (each within the scatter of the next).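

In this assay a six-membered aromatic ring of carbon only, 4-methylphenyl, now stands at this place, and with no ring nitrogen and no hydrogen-bond acceptor in the group the steps remain within the scatter, with a 1.7-fold lower number from compound 3 to compound 4 (0.22 log units; within the scatter) and no change at the digits printed from compound 2 to compound 4 (within the scatter) and also a 1.3-fold lower number from compound 1 to compound 4 (0.12 log units; within the scatter) printed as such. All four groups at this place on the shared core are therefore not separated from each other in this read-out. No measured evidence bears on why this is so.

Open, as far as these compounds go, is whether an amine, a carboxylic acid or a longer chain at this place would leave the scatter.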